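Swapping methoxy for fluoro on a kinase inhibitor

The source may report more compounds than this note shows. Statements on the series, on what has been measured and on what is new or still open speak of the compounds shown alone.

Compound 1 `COc1ccc(-c2ccnc(Nc3ccc([N+](=O)[O-])cc3)n2)cc1` sits at the lower of the two plain numbers shown here. In an assay on isolated protein for inhibition of phosphatidylinositol 4,5-bisphosphate 3-kinase catalytic subunit beta isoform (Homo sapiens) (on this read-out lower numbers stand for stronger inhibition and higher numbers for weaker inhibition), compound 1 gives 537 nM. Compound 2 `Clc1ccc(Nc2nccc(-c3ccc(Br)cc3)n2)c(Cl)c1` gives 673 nM in this assay, a value within the scatter of compound 1, so the two cannot be told apart. Compound 3 `COc1cccc(Nc2nccc(-c3ccc(F)cc3)n2)c1` reaches only a limit of this assay, > 1000 nM, which is a boundary of the measurement and not a number (the limit of > 1000 nM in this assay, at which 1 of the 3 values shown sits).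

Compound 4 `O=[N+]([O-])c1ccc(Nc2nccc(-c3ccc(F)cc3)n2)cc1` is not yet measured. It differs from compound 1 in one place: fluoro in place of methoxy on an aromatic carbon. Compound 3 also carries a 4-fluorophenyl group, but it differs from compound 1 elsewhere as well, so its limit does not isolate this single change. For the measured compounds named here, no pair of measured compounds differs by exactly this change, so there is no measured step to lean on. Compound 4 is expected to end up close to compound 1 or somewhat weaker, with the step of a 1.4-fold higher number from compound 1 to compound 4 (0.15 log units; within the scatter) expected to lie around the edge of the usual scatter. Compound 4 is estimated at 750 nM in this assay, within a range from 250 nM to 2200 nM.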

Compound 4, half-maximal inhibitory concentration: 863 nM
Beside the measured number, compound 4's estimate is 1.2-fold (0.06 log units) below it, within the range that was stated.
By their numbers in this assay, from the lowest: compounds 1, 2 and 4 (each within the scatter of the next). At a limit, above all of these: compound 3.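

The change from 4-methoxyphenyl to 4-fluorophenyl can now be read on its own in this assay, with the rest of the molecule held the same, and it gives a 1.6-fold higher number from compound 1 to compound 4 (0.21 log units; within the scatter). This step lies within the scatter, so on the core of compound 1 the methoxy and fluoro groups cannot be told apart at this position, even though they differ in size and only methoxy counts a hydrogen-bond acceptor. Compound 3 also carries the 4-fluorophenyl group, but it differs from compound 1 in more than one place and its value is a limit of the assay, so it could not show what this single change does: the limit of > 1000 nM in this assay, at which 1 of the 4 values shown sits.

Still open, from the compounds shown here alone, is whether a more different group at this position, such as an amine, a carboxylic acid or a longer chain like butoxy, would move the number beyond the scatter. For the compounds shown here, only one pair shows the swap of methoxy for fluoro, so it also remains open whether the swap would stay this small with other groups elsewhere on the core.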